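The source may hold more compounds than are shown below. What is called first, only, known or untested is meant among the compounds shown, and "the series" means these compounds.

Measured compounds:
- compound 1 `COc1cc(Cl)cc(-c2nn(-c3cccc(NC(=O)c4ccc(Cl)c(Cl)c4)c3)cc2-c2ccncc2)c1`: 78.5%
- compound 2 `O=C(Nc1cccc(-n2cc(-c3ccncc3)c(-c3cc(O)cc(Cl)c3)n2)c1)Nc1ccc(Cl)c(C(F)(F)F)c1`: 23.8%

In a functional assay on SK-MEL-5 cells (Homo sapiens) for inhibition, read by sulforhodamine B assay, with a stated time of 48 h, tested at 10 uM (on this read-out lower numbers stand for a stronger effect and higher numbers for a weaker effect at the one concentration tested), compound 1 gives 78.5%, the higher of the two numbers; compound 2 gives 23.8%, a value well apart from it. Compound 3 `COc1cc(Cl)cc(-c2nn(-c3cccc(NC(=O)Nc4ccc(Cl)c(C(F)(F)F)c4)c3)cc2-c2ccncc2)c1` is not yet measured. It differs from compound 1 by (4-chloro-3-(trifluoromethyl)phenyl)amino in place of 3,4-dichlorophenyl on a carbonyl carbon. The change brings in the same (4-chloro-3-(trifluoromethyl)phenyl)amino group that compound 2 carries, so a downward step beyond the scatter is expected, though its size remains uncertain. Compound 3 is expected to reach about 40%, estimated between 20% and 70%, which would mean a number 38.5 percentage points lower from compound 1 to compound 3 (beyond the scatter).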

Compound 3, a percentage reported as activity, at one concentration (the size of the read-out at that concentration, not a potency): -71.2%
The estimate for compound 3 lay 111.2 percentage points above the measured number, outside the stated range (below it).
By their numbers in this assay, from the lowest: compound 3; then compound 2; then compound 1.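

In this assay, the exchange of 3,4-dichlorophenyl for (4-chloro-3-(trifluoromethyl)phenyl)amino on a carbonyl carbon gives a number 149.7 percentage points lower from compound 1 to compound 3 (beyond the scatter), so this one place carries a very large change. With that group in place, methyl on the oxygen also counts, giving a number 95 percentage points lower from compound 2 to compound 3 (beyond the scatter). Compound 3, at -71.2%, therefore stands lowest of the three, the strongest effect at the one concentration tested.

Nothing given here accounts for the size of these steps. On these data alone, it also remains open how an ethyl group or a longer chain on that oxygen would read.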